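Swapping the benzamide aryl for a dichloropyrimidine

The compounds below may be only part of what the source reports. "The series", "measured", "known", "first", "only" and "open" are said of these compounds alone.

Compound 1, `O=C(Nc1cccc(-c2oc3cc(-c4ccc(F)cc4)ccc3c(=O)c2O)c1)c1ccc(F)cc1`, in a functional assay on A549 cells (Homo sapiens) for antiproliferative activity, read by CCK-8 assay, with a stated time of 72 h (on this read-out higher numbers stand for weaker inhibition and lower numbers for stronger inhibition), gives 6930 nM.
Compound 2, `COc1ccc(C(=O)Nc2cccc(-c3oc4cc(-c5ccc(F)cc5)ccc4c(=O)c3O)c2)cc1`, in this assay gives 8700 nM.
Compound 3, `CCc1ccc(C(=O)Nc2cccc(-c3oc4cc(-c5ccc(F)cc5)ccc4c(=O)c3O)c2)cc1`, in this assay gives 18500 nM.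

Compound 2 holds the second-highest of the three numbers in this assay: compound 1 is nearest, a 1.3-fold higher number from compound 1 to compound 2 (0.10 log units; within the scatter), while compound 3 is furthest, a 2.1-fold higher number from compound 2 to compound 3 (0.33 log units; beyond the scatter). Compound 4, `O=C(Nc1cccc(-c2oc3cc(-c4ccc(F)cc4)ccc3c(=O)c2O)c1)c1cnc(Cl)nc1Cl`, is not yet measured; its change from compound 2 is 2,4-dichloropyrimidin-5-yl in place of 4-methoxyphenyl on a carbonyl carbon. The measured steps all concern a small group on the same aromatic ring, with a 2.7-fold higher number from compound 1 to compound 3 (0.43 log units; beyond the scatter) the largest, so none directly covers exchanging that ring for the 2,4-dichloropyrimidin-5-yl group. Those steps are modest at most, so compound 4 is expected to land near compound 2, with a 1.0-fold higher number from compound 2 to compound 4 (0.01 log units; within the scatter) within the scatter, and an estimated 9000 nM in this assay, ranging from 3000 nM to 27000 nM.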

Compound 4, half-maximal inhibitory concentration: > 100000 nM
Compound 4 was reported as a limit; the forecaster's own chance of this, stated with the estimate: 15%; middle value at least 11-fold (1.04 log units) away from the limit.
By their numbers in this assay, from the lowest: compounds 1 and 2 (each within the scatter of the next); then compound 3. At a limit, above all of these: compound 4.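

Exchanging the whole ring on the carbonyl carbon moves the number much further than the small-group changes did, with an at least 11-fold higher number from compound 2 to compound 4 (1.06 log units; beyond the scatter), an at least 14-fold higher number from compound 1 to compound 4 (1.15 log units; beyond the scatter) and an at least 5.4-fold higher number from compound 3 to compound 4 (0.73 log units; beyond the scatter). The value of compound 4 is a limit, not a number: the limit of > 100000 nM in this assay, at which 1 of the 4 values shown sits. So this place accepts the 4-fluorophenyl, 4-methoxyphenyl and 4-ethylphenyl groups with modest shifts at most, but not every six-membered aromatic ring.

The compounds shown do not separate the two ring nitrogens from the two chlorines as the source of the loss. An unsubstituted pyrimidine, a dichlorophenyl ring or a pyrimidine carrying an amine instead of chlorine would bear on this.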